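Benzylsulfanyl series: chloro on the benzyl ring, rat artery

The source may report more compounds than this note shows. Statements on the series, on what has been measured and on what is new or still open speak of the compounds shown alone.

Measured so far:
compound 1 `COc1ccc(C2N=C(SCc3ccccc3Cl)NC(C)=C2C(=O)Nc2ccc(F)cc2)cc1OC` — 6.2%
compound 2 `CC1=C(C(=O)Nc2ccc(F)cc2)C(c2ccc([N+](=O)[O-])cc2)N=C(SCc2ccccc2)N1` — 7.2%
compound 3 `CC1=C(C(=O)Nc2ccc(Br)cc2)C(c2ccc(Cl)cc2Cl)N=C(SCc2ccccc2)N1` — 3.6%

All three numbers come from a functional assay on the whole organism (artery, strain albino) with Rattus norvegicus as the target, with a stated time of 30 min, at a dose of 10 mg/kg by the oral route; a higher number here means more inhibition at the dose given (going by the name of the read-out), a lower number less inhibition. Compound 1 gives 6.2%, compound 2 gives 7.2% and compound 3 gives 3.6%. On the numbers shown, compound 3 has the lowest of the three values, but its gap to compound 1 and its gap to compound 2 both lie within the scatter of this assay, so the three compounds are not separated from one another by these data. Among the compounds with values here, no two of the measured compounds differ in only one place, so no single step within the measured set can be read.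

The next compound is compound 4 `CC1=C(C(=O)Nc2ccc(Br)cc2)C(c2ccc(Cl)cc2Cl)N=C(SCc2cccc(Cl)c2)N1`. It differs from compound 3 as follows: chloro in place of hydrogen on an aromatic carbon. The change is a chloro in place of hydrogen on an aromatic carbon of the benzyl group; the benzylsulfanyl of compound 3 becomes (3-chlorobenzyl)sulfanyl.

Within the data shown here, no measured step bears on this change. Given that compound 1, compound 2 and compound 3 all sit low in this assay with no separation beyond the scatter, no step beyond the scatter is expected from compound 3 to compound 4, and the estimated step is a number 1.4 percentage points higher from compound 3 to compound 4 (within the scatter). Compound 4 is expected to give about 5% in this assay, estimated within a range from 0% to 15%.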

Compound 4, a percentage reported as inhibition, in the whole organism at one dose (the size of the read-out at that dose, not a potency): 3.1%
Beside the measured number, compound 4's estimate is 1.9 percentage points above it, within the range that was stated.
By their numbers in this assay, from the lowest: compounds 4, 3, 1 and 2 (each within the scatter of the next).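

Within the data shown here, this pair is the first comparison that differs in one place: in this assay, replacing benzylsulfanyl with (3-chlorobenzyl)sulfanyl gives a number 0.5 percentage points lower from compound 3 to compound 4 (within the scatter). A chloro on this aromatic carbon, meta to a large group, therefore does not separate the two compounds, and this single change gives no sign of a route out of the low range of the series at this dose. Nothing measured here speaks to a cause for this result.

The other pairs differ in more than one place and cannot be read as steps. Going by these compounds, it remains open whether an amine or a carboxylic acid on this aromatic carbon, or a longer chain in place of the benzyl group, would give a step beyond the scatter.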